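The source may report more compounds than this note shows. Statements on the series, on what has been measured and on what is new or still open speak of the compounds shown alone.

Among the measured compounds shown here, in a functional assay on the whole organism for positive allosteric modulation, with Rattus norvegicus as the target (on this read-out lower numbers stand for an effect already at smaller amounts and higher numbers for an effect only at larger amounts of compound), compound 3 `Cc1ccc(C2=NCCNc3c2c(C)nn3C)cc1` is the one compound that yields a number, 2.5 mg/kg. Compound 1 `Cc1nn(C)c2c1C(c1cccc(Cl)c1)=NCCN2CCCN(C)C` gives only a limit, > 10 mg/kg. Compound 2 `Cc1nn(C)c2c1C(c1ccccc1)=NCCN2CCCN(C)C` likewise gives only a limit, > 10 mg/kg. For the measured compounds named here, the step from compound 1 to compound 2 is a step that the two limits leave unreadable from compound 1 to compound 2, so the single measured step offers no readable size. Both of those values sit at the limit of > 10 mg/kg in this assay, at which 2 of the 3 values shown sit.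

Compound 4 `Cc1ccc(C2=NCCN(CCCN(C)C)c3c2c(C)nn3C)cc1` differs from compound 3 in one place: 3-(dimethylamino)propyl in place of hydrogen on a nitrogen on an aromatic ring in a ring. Going by the values given here, no measured step covers this change; the step from compound 1 to compound 2 concerns hydrogen in place of chloro on an aromatic carbon and does not bear on it. Because compound 1 and compound 2 with that group on the ring nitrogen both sit at the limit of > 10 mg/kg in this assay, at which 2 of the 3 values shown sit, while compound 3 with hydrogen there gives a number, compound 4 is expected to act only at a larger dose and may itself reach only a limit. Compound 4 is therefore expected to show a step of a 4.0-fold higher number from compound 3 to compound 4 (0.60 log units; beyond the scatter). The estimate for compound 4 is 10 mg/kg, with a range from 3 mg/kg to 30 mg/kg.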

Compound 4, minimum effective dose: > 10 mg/kg
Compound 4: a limit, no number; the forecaster's own chance of this, stated with the estimate: 60%; the middle value sits exactly at the limit.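

With the 4-methylphenyl group held in place, 3-(dimethylamino)propyl in place of hydrogen on the ring nitrogen gives an at least 4.0-fold higher number from compound 3 to compound 4 (0.60 log units; beyond the scatter) in this assay. This is the first pair shown that isolates this change at this position, and the direction of the step is readable even though compound 4 gives only a limit. The steps among compound 1, compound 2 and compound 4 join two limits and cannot be read, and the chain-bearing compounds with 3-chlorophenyl, phenyl and 4-methylphenyl groups all share one limit: the limit of > 10 mg/kg in this assay, at which 3 of the 4 values shown sit.

From the compounds shown here alone, the true size of the step remains open, since its upper end is not defined. Going by these compounds, it is also open whether a smaller group on this nitrogen, such as ethyl, or a shorter chain, such as 2-(dimethylamino)ethyl, would still give a number in this assay.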